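Removing a Methyl from an Oxygen on the Shared Core

A few compounds are considered here, and "the series" means these few. Any claim that something is new, unique, unknown or untested is made for them only; others in the source may bear on it.

Measured compounds:
- compound 1, `Cc1cc(O)cc(-c2nn(CC#N)cc2-c2ccnc(-c3ccc(Oc4ccccc4)cc3)c2)c1`: 12200 nM
- compound 2, `COc1cc(C)cc(-c2nn(CC#N)cc2-c2ccnc(-c3ccc(N(C)C)cc3)c2)c1`: 127000 nM

Of the compounds shown here, two have been tested in a functional assay on NCI-H226 cells (Homo sapiens) for inhibition, read by sulforhodamine B assay, with a stated time of 48 h; a lower number here means a stronger inhibitor of growth, a higher number a weaker inhibitor of growth. Compound 1 gives 12200 nM, while compound 2 gives 127000 nM, the highest of the two numbers; the gap between compound 1 and compound 2 lies beyond the scatter of repeat measurements. The two differ in more than one place, so no single change can be read from that gap.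

Compound 3, `Cc1cc(O)cc(-c2nn(CC#N)cc2-c2ccnc(-c3ccc(N(C)C)cc3)c2)c1`, is not yet measured. It is made from compound 2 by one change: hydrogen in place of methyl on an oxygen on an aromatic ring, turning the 3-methoxy-5-methylphenyl group into a 3-hydroxy-5-methylphenyl group. Among the measured compounds shown here, no measured pair in this assay shows this change on its own, so its effect here is unknown. Compound 1 does carry the hydroxy form, but it also carries a different group elsewhere.

A small to moderate step toward a lower number is expected, a 2.1-fold lower number from compound 2 to compound 3 (0.33 log units; beyond the scatter), though a move in either direction within the scatter would not be surprising. For compound 3 in this assay the estimate is 60000 nM, within 15000 nM to 200000 nM.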

Compound 3, concentration for total growth inhibition: 21800 nM
Compound 3: the middle estimate sits 2.8-fold (0.44 log units) above what was measured, and the stated range covers the measured number.
By their numbers in this assay, from the lowest: compounds 1 and 3 (each within the scatter of the next); then compound 2.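

With the dimethylamino group held fixed, hydrogen in place of methyl on an oxygen on an aromatic ring now has a reading of its own in this assay (a 5.8-fold lower number from compound 2 to compound 3 (0.77 log units; beyond the scatter)), so turning methoxy into hydroxy on this ring moves the number by more than repeat measurements would. Among the compounds shown here, compound 3 also links compound 1 and compound 2, which differ in two places: with the hydroxy form on both sides, dimethylamino in place of phenoxy on an aromatic carbon leaves the two numbers within the scatter of each other (a 1.8-fold higher number from compound 1 to compound 3 (0.25 log units; within the scatter)), so of the two single changes that connect them through compound 3, only the one on the oxygen gives a step beyond the scatter. Nothing available explains the size of this step.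

The compounds shown leave open whether the change from methoxy to hydroxy gives a similar step when phenoxy replaces dimethylamino, as that pair has only its hydroxy member here. They also leave open how a larger group on the same oxygen, such as ethyl, or an amine in place of the hydroxy group would read in this assay on the shared core.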